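The source may hold more compounds than are shown below. What is called first, only, known or untested is meant among the compounds shown, and "the series" means these compounds.

Measured so far:
Compound 1 `CCNc1cnc2ccc(-c3cnc(OC)c(NS(=O)(=O)c4ccc(F)cc4F)c3)cc2c1OC`: 1850 nM
Compound 2 `COc1ccc(CNc2cnc3ccc(-c4cnc(OC)c(NS(=O)(=O)c5ccc(F)cc5F)c4)cc3c2OC)cc1`: 10200 nM

These numbers come from a functional assay on HCT-116 cells (Homo sapiens) for antiproliferative activity, read by sulforhodamine B assay, with a stated time of 72 h; a higher number here means a weaker inhibitor, a lower number a stronger inhibitor. Compound 2 has the higher of the two numbers at 10200 nM, which makes it the weaker inhibitor, and the gap to compound 1 lies beyond the scatter.

The next compound, compound 3 `COc1ncc(-c2ccc3ncc(NC(C)=O)c(OC)c3c2)cc1NS(=O)(=O)c1ccc(F)cc1F`, keeps the shared core and changes one group: acetyl in place of 4-methoxybenzyl on a nitrogen on an aromatic ring.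

Among the measured compounds shown here, only one measured step bears on this: a 5.5-fold higher number from compound 1 to compound 2 (0.74 log units; beyond the scatter). There, 4-methoxyphenyl came in place of methyl on a saturated chain carbon bound to a nitrogen on an aromatic ring. Compound 3 also lacks the 4-methoxyphenyl, so a move of about the size of a 5.5-fold higher number from compound 1 to compound 2 (0.74 log units; beyond the scatter), but in the opposite direction, is expected in this assay. For the measured compounds named here, this guide is weak, since no measured compound carries a carbonyl and a single step is thin evidence.

The expected result is a 5.1-fold lower number from compound 2 to compound 3 (0.71 log units; beyond the scatter). For compound 3 the estimated value is 2000 nM, with an expected range from 500 nM to 8000 nM.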

Compound 3, half-maximal inhibitory concentration: 550 nM
Estimate against measurement, compound 3: 3.6-fold (0.56 log units) above; measured number inside the range.
By their numbers in this assay, from the lowest: compound 3; then compound 1; then compound 2.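

In this assay, swapping the group on this nitrogen has a large effect: putting acetyl in place of 4-methoxybenzyl gives a 19-fold lower number from compound 2 to compound 3 (1.27 log units; beyond the scatter). The comparison with ethyl adds something the earlier pair could not show, as acetyl in place of ethyl still gives a 3.4-fold lower number from compound 1 to compound 3 (0.53 log units; beyond the scatter), so removing the 4-methoxyphenyl ring is not the whole story and a carbonyl-bearing group on this nitrogen outperforms a plain alkyl chain in this single pair; with both of its steps beyond the scatter, compound 3 is the strongest inhibitor of the three. Nothing measured here explains why these groups differ.

The compounds shown leave open whether this result belongs to acetyl alone or extends to other acyl groups, such as propanoyl or benzoyl, or to a methanesulfonyl group on the same nitrogen. They also leave open how the unsubstituted amine would compare, which would show how either the ethyl or the acetyl group compares with having no added group on this nitrogen at all.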